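The source may report more compounds than this note shows. Statements on the series, on what has been measured and on what is new or still open speak of the compounds shown alone.

Working notes on the series. All three measured compounds share one core and differ only in the group on one aromatic carbon. Compound 1 `c1ccc(-c2cccc3c2CCC3c2ncc[nH]2)nc1` carries pyridin-2-yl there; in a functional assay on CHO cells for agonist activity at Alpha-1A adrenergic receptor (Homo sapiens), read by FLIPR and calcium flux (a lower number here means that less compound is needed, a higher number that more compound is needed for the effect), compound 1 gives 1150 nM. Compound 2 `c1cc(-c2ccn[nH]2)c2c(c1)C(c1ncc[nH]1)CC2` carries 1H-pyrazol-5-yl, and in this assay compound 2 gives 52 nM. Compound 3 `Cc1oncc1-c1cccc2c1CCC2c1ncc[nH]1` carries 5-methyl-1,2-oxazol-4-yl, and in this assay compound 3 gives 111 nM. Compound 3 thus stands second highest of the three numbers: a 10-fold lower number from compound 1 to compound 3 (1.02 log units; beyond the scatter), whereas a 2.1-fold higher number from compound 2 to compound 3 (0.33 log units; beyond the scatter). Both five-membered rings sit well below the pyridin-2-yl of compound 1, as also seen in a 22-fold lower number from compound 1 to compound 2 (1.34 log units; beyond the scatter).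

Compound 4 `c1cc(-c2ncco2)c2c(c1)C(c1ncc[nH]1)CC2` differs from compound 3 in one place: 1,3-oxazol-2-yl in place of 5-methyl-1,2-oxazol-4-yl on an aromatic carbon. This exchanges one five-membered aromatic ring with two hetero atoms for another, so the step that bears on it most directly is the modest one from compound 2 to compound 3, while the large steps from compound 1 mark how far a six-membered ring lies away. A step of modest size in this assay is therefore expected, in either direction, with the number for compound 4 expected to remain well below that of compound 1. Compound 4 is expected to give 100 nM in this assay, within a range of 35 nM to 300 nM. The expected step is a 1.1-fold lower number from compound 3 to compound 4 (0.05 log units; within the scatter).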

Compound 4, half-maximal effective concentration: 170 nM
Estimate against measurement, compound 4: 1.7-fold (0.23 log units) below; the range from low to high includes it.
By their numbers in this assay, from the lowest: compound 2; then compounds 3 and 4 (each within the scatter of the next); then compound 1.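

In this assay, 1,3-oxazol-2-yl and 5-methyl-1,2-oxazol-4-yl cannot be told apart at this aromatic carbon (a 1.5-fold higher number from compound 3 to compound 4 (0.19 log units; within the scatter)), even though the entering ring has one heavy atom fewer and a different point of attachment. The 1,3-oxazol-2-yl of compound 4 still stands apart from the 1H-pyrazol-5-yl (a 3.3-fold higher number from compound 2 to compound 4 (0.51 log units; beyond the scatter)) and from the pyridin-2-yl (a 6.8-fold lower number from compound 1 to compound 4 (0.83 log units; beyond the scatter)), so all three five-membered rings shown now lie below pyridin-2-yl, with a third ring type confirming that gap. No measurement at hand accounts for these differences.

The compounds shown leave open whether the low numbers require a five-membered aromatic ring at all, since a plain phenyl, a morpholine or an amine at this carbon would test that. They also leave open whether pyrimidin-2-yl would stand with pyridin-2-yl.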